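A few compounds are considered here, and "the series" means these few. Any claim that something is new, unique, unknown or untested is made for them only; others in the source may bear on it.

Of the compounds shown here, three of a shared core have already been measured. Compound 1 `O=C1C=C(Nc2ccc(I)cc2)C(=O)c2c1nc1n2[C@H]2OC[C@@H](O)[C@H]2OC1` gives 2230 nM in a functional assay on MCF7 cells (Homo sapiens) for inhibition, read by sulforhodamine B assay; a higher number here means a weaker inhibitor, a lower number a stronger inhibitor. Compound 2 `COc1cccc(NC2=CC(=O)c3c(nc4n3[C@H]3OC[C@@H](O)[C@H]3OC4)C2=O)c1` gives 3830 nM in this assay; this is the highest of the two plain numbers, yet compound 1 sits nearest to it and the gap between them stays within the usual scatter. For compound 3 `O=C1C=C(NCc2ccccc2)C(=O)c2c1nc1n2[C@H]2OC[C@@H](O)[C@H]2OC1` the assay reports only a limit, > 8000 nM, not a number. One step links these results: an at least 3.5-fold higher number from compound 1 to compound 3 (0.55 log units; beyond the scatter), a step that was at least modest and lay beyond the scatter, as shown by the limit of > 8000 nM in this assay, at which 1 of the 3 values shown sits.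

Compound 4 `O=C1C(NC2CCCC2)=CC(=O)c2c1nc1n2[C@H]2OC[C@@H](O)[C@H]2OC1` has not been measured. It differs from compound 2 as follows: cyclopentyl in place of 3-methoxyphenyl on an amine nitrogen. Going by the values given here, the one measured step that bears on this change, from compound 1 to compound 3, replaced a ring that is aromatic with a group that is not, and raised the number at least modestly. A rise in this assay of a similar kind is therefore expected for compound 4, a 2.3-fold higher number from compound 2 to compound 4 (0.37 log units; beyond the scatter). Compound 4 is estimated at 9000 nM, with a likely range from 3000 nM to 25000 nM.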

Compound 4, half-maximal inhibitory concentration: > 16000 nM
Compound 4: no number, only a limit; the forecaster's own chance of this, stated with the estimate: 50%; middle value at least 1.7-fold (0.24 log units) away from the limit.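

In this assay compound 4 gives only a limit, > 16000 nM, and not a number. Replacing (3-methoxyphenyl)amino with cyclopentylamino still brings an at least 4.1-fold higher number from compound 2 to compound 4 (0.62 log units; beyond the scatter), so a ring that is not aromatic on this amine nitrogen goes with a weaker inhibitor, something the earlier step to benzyl could not show, since benzyl still carries an aromatic ring. The full size of this step remains unknown because the result for compound 4 is a limit: the limit of > 16000 nM in this assay, at which 1 of the 4 values shown sits.

The compounds shown leave open whether cyclopentyl itself matters or whether any group without an aromatic ring would behave alike, such as cyclohexyl or a longer chain. They also leave open how plain phenyl, with no methoxy or iodine on it, would compare.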